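The source may hold more compounds than are shown below. What is called first, only, known or untested is meant among the compounds shown, and "the series" means these compounds.

Working notes on the series.

Compound 1 `COc1ccc(NC(=O)NCc2cnc3scc(-c4ccc(Br)cc4)n23)cc1` and compound 2 `O=C(NCc1cnc2scc(-c3ccc(Br)cc3)n12)NC1CCCCC1` share one core and differ only at the urea end. In an assay on isolated protein for inhibition of Indoleamine 2,3-dioxygenase 1 (Homo sapiens), with a stated time of 30 min (on this read-out lower numbers stand for stronger inhibition and higher numbers for weaker inhibition), compound 1 gives 190 nM. In the same measurement compound 2 gives 1800 nM, which is the highest of the two numbers shown. Within the data shown here, the single step between them, a 9.5-fold higher number from compound 1 to compound 2 (0.98 log units; beyond the scatter), is the only measured change at this position. Compound 3 `CCOC(=O)c1cnc2scc(-c3ccccc3)n12` carries an ester in place of the urea chain. In this assay compound 3 gives only > 100000 nM, a limit of the assay rather than a number, so it adds nothing on the urea substituent (the limit of > 100000 nM in this assay, at which 1 of the 3 values shown sits).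

Compound 4 `N#Cc1ccc(NC(=O)NCc2cnc3scc(-c4ccc(Br)cc4)n23)cc1` is not yet measured. It differs from compound 2 as follows: 4-cyanophenyl in place of cyclohexyl on an amide-type nitrogen. The change returns the group on the amide-type nitrogen to one six-membered aromatic ring of carbon only, which is the direction opposite to the measured step from compound 1 to compound 2. On that basis compound 4 is expected to show a lower number than compound 2, with the step from compound 2 estimated as a 7.2-fold lower number from compound 2 to compound 4 (0.86 log units; beyond the scatter). The estimate for compound 4 in this assay is 250 nM, with a range from 80 nM to 800 nM.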

Compound 4, half-maximal inhibitory concentration: 77 nM
Beside the measured number, compound 4's estimate is 3.2-fold (0.51 log units) above it; measured number below the stated range.
By their numbers in this assay, from the lowest: compound 4; then compound 1; then compound 2. At a limit, above all of these: compound 3.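

In this assay, both aromatic groups on the amide-type nitrogen now give lower numbers than cyclohexyl, and 4-cyanophenyl in place of cyclohexyl gives a 23-fold lower number from compound 2 to compound 4 (1.37 log units; beyond the scatter). Among these compounds, the substituent on the aromatic ring also matters, which the earlier compounds could not show: cyano in place of methoxy on an aromatic carbon gives a 2.5-fold lower number from compound 1 to compound 4 (0.39 log units; beyond the scatter). Nothing measured here accounts for either step.

The compounds shown leave open how a plain phenyl group, or a phenyl ring carrying a carboxylic acid or an amine in place of the nitrile, would read on this nitrogen. From the compounds shown here alone, whether a benzyl group on the same nitrogen would keep the number as low as the aromatic rings do also remains open.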